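The compounds below may be only part of what the source reports. "The series", "measured", "known", "first", "only" and "open" are said of these compounds alone.

Three compounds share one large fused core and differ only in the aromatic group hanging from it. Compound 1 `Cc1nc2c3ccccc3ccc2c2nc3c(ccc4ccccc43)c(-c3nccnc3N)c12` carries a 3-aminopyrazin-2-yl group there, and in a functional assay, with a stated time of 90 s (on this read-out lower numbers stand for stronger inhibition and higher numbers for weaker inhibition), compound 1 gives 134 ug/mL. Compound 2 `Cc1nc2c3ccccc3ccc2c2nc3c(ccc4ccccc43)c(-c3cc([N+](=O)[O-])ccc3N)c12` carries a 2-amino-5-nitrophenyl group instead, and in this assay compound 2 gives 110 ug/mL. Compound 3 `Cc1nc2c3ccccc3ccc2c2nc3c(ccc4ccccc43)c(-c3ccccc3N)c12` carries a plain 2-aminophenyl group, and in this assay compound 3 gives 125 ug/mL. Compound 3 thus stands second highest of the three numbers, though all three lie so close together that none can be told apart: the step of a 1.1-fold lower number from compound 1 to compound 3 (0.03 log units; within the scatter), the step of a 1.1-fold higher number from compound 2 to compound 3 (0.06 log units; within the scatter) and the step of a 1.2-fold lower number from compound 1 to compound 2 (0.09 log units; within the scatter) are each within the scatter.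

Compound 4 `Cc1ccc(-c2c3ccc4ccccc4c3nc3c2c(C)nc2c4ccccc4ccc32)cc1` takes the next step from compound 3: 4-methylphenyl in place of 2-aminophenyl on an aromatic carbon. With this change the amino group, the only hydrogen-bond donor in the variable part, disappears. The measured steps bear on it only loosely: swapping the whole aromatic group or removing the nitro group left the numbers essentially where they were, which suggests that this position tolerates variation, but none of those steps removed the amino group. The expectation is therefore a step of a 1.1-fold higher number from compound 3 to compound 4 (0.05 log units; within the scatter) in this assay for compound 4, no larger than the scatter. Compound 4 is expected to give about 140 ug/mL in this assay, most likely between 70 ug/mL and 280 ug/mL.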

Compound 4, half-maximal inhibitory concentration: 192 ug/mL
Estimate against measurement, compound 4: 1.4-fold (0.14 log units) below, and the stated range covers the measured number.
By their numbers in this assay, from the lowest: compounds 2, 3, 1 and 4 (each within the scatter of the next).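

For the compounds shown here, compound 4 is the first of the set whose group on this aromatic carbon, 4-methylphenyl, has no amino group and counts 0 hydrogen-bond donors, yet in this assay the change gives a 1.5-fold higher number from compound 3 to compound 4 (0.19 log units; within the scatter). The comparisons with the two other amino-bearing groups tell the same story, with a 1.7-fold higher number from compound 2 to compound 4 (0.24 log units; within the scatter) and a 1.4-fold higher number from compound 1 to compound 4 (0.16 log units; within the scatter). So on this read-out, an amino group on the aromatic substituent is not needed to stay within the scatter of the other three compounds, and this position now tolerates a group with neither a hydrogen-bond donor nor a hydrogen-bond acceptor, though nothing available here explains the values of any of the four compounds.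

Going by these compounds, because this change removes the amino group and adds a methyl group in one step, the share of each stays unknown, and a plain phenyl group would be needed to separate them. On these data alone, all four groups are also six-membered aromatic rings, so it remains open whether a carboxylic acid on that ring, a saturated ring such as morpholine or a longer alkyl chain would move the number beyond the scatter.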